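Methylation of an aromatic amine in a benzamide series

A few compounds are considered here, and "the series" means these few. Any claim that something is new, unique, unknown or untested is made for them only; others in the source may bear on it.

Compound 1 `CNc1cc(OC)c(C(=O)NCCN(C)Cc2ccccc2)cc1Cl` was tested in a functional assay on the whole organism with Rattus norvegicus as the target (a lower number here means that less compound is needed, a higher number that more compound is needed for the effect), where compound 1 gives 0.21 mg/kg. Compound 2 `COc1cc(N(C)C)c(Cl)cc1C(=O)NCCN(C)Cc1ccccc1` carries one change relative to compound 1, namely (methyl in place of hydrogen on a nitrogen on an aromatic ring), and in this assay compound 2 gives 0.54 mg/kg. That single change produced a 2.6-fold higher number from compound 1 to compound 2 (0.41 log units; beyond the scatter).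

Compound 3 `COc1cc(N)c(Cl)cc1C(=O)NCC1CCCN1Cc1ccccc1` belongs to a second core; how its core differs from that of compound 1 is not broken down here. In this assay compound 3 gives 1.1 mg/kg, the highest number of the three measured compounds. Compound 4 `CNc1cc(OC)c(C(=O)NCC2CCCN2Cc2ccccc2)cc1Cl` is not yet measured. It differs from compound 3 by methyl in place of hydrogen on a nitrogen on an aromatic ring. For the measured compounds named here, this is the same kind of change as the one from compound 1 to compound 2, but not the same: in compound 1 the nitrogen's other neighbours are aromatic carbon and saturated chain carbon, so the change reads methylamino to dimethylamino, whereas in compound 3 the nitrogen's only other neighbour is aromatic carbon, so the change reads amino to methylamino.

Because the earlier step was a 2.6-fold higher number from compound 1 to compound 2 (0.41 log units; beyond the scatter), the same kind of change on compound 3 is expected to raise the number, though the differing surroundings of the nitrogen and the change of core leave the size uncertain; the step from compound 3 to compound 4 is estimated at a 1.6-fold higher number from compound 3 to compound 4 (0.21 log units; within the scatter). Compound 4 is therefore expected to give about 1.8 mg/kg, within a range from 0.7 mg/kg to 4.5 mg/kg.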

Compound 4, dose for half-maximal effect: 0.94 mg/kg
Estimate against measurement, compound 4: 1.9-fold (0.28 log units) above; measured number inside the range.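

On the second core, methyl in place of hydrogen on a nitrogen on an aromatic ring gave a 1.2-fold lower number from compound 3 to compound 4 (0.07 log units; within the scatter) in this assay, so the rise in the number seen on the first core did not reappear here. Set side by side, the two steps differ, which shows that in this series the size of the step measured on one core cannot simply be carried to the other: the same change on two cores in this assay, a 2.6-fold higher number (0.41 log units; beyond the scatter) from compound 1 to compound 2 and a 1.2-fold lower number (0.07 log units; within the scatter) from compound 3 to compound 4, 3.0-fold (0.48 log units) apart, beyond the scatter of two such steps

This does not show what separates the two steps, since they differ both in the core and in the surroundings of the nitrogen, with methylamino to dimethylamino on one side and amino to methylamino on the other.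

The compounds shown leave open how a dimethylamino group would read on the core of compound 3 and how a plain amino group would read on the core of compound 1, two comparisons that would set the core apart from the state of the nitrogen. Also open, as far as these compounds go, is whether other groups on that nitrogen, such as an ethyl group, a longer chain or an acetyl group, would follow either step.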